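Trading One Aryl Group for Another on the Shared Core

The compounds below may be only part of what the source reports. "The series", "measured", "known", "first", "only" and "open" are said of these compounds alone.

Of the compounds shown here, three that share one core have been tested in a functional assay on A549 cells (Homo sapiens) for antiproliferative activity, read by MTT assay; on this read-out lower numbers stand for stronger inhibition and higher numbers for weaker inhibition. Compound 1 `COc1ccc(-c2cc(CN(c3nc4ccc(F)cc4s3)c3nc4ccc(OC)cc4s3)on2)cc1` gives 38800 nM. Compound 2 `COc1ccc2nc(N(Cc3cc(-c4cc(OC)c(OC)c(OC)c4)no3)c3nc4ccc(F)cc4s3)sc2c1` differs from it only at the aryl group attached to the five-membered ring, and in this assay compound 2 gives 61900 nM. Among the measured compounds shown here, that change, a 1.6-fold higher number from compound 1 to compound 2 (0.20 log units; within the scatter), is the only measured step so far, and it stays within the scatter. Compound 3 `FC(F)(F)Oc1ccc(-c2cc(CN(c3ncccn3)c3nc4ccccc4s3)on2)cc1` carries a different pair of groups on the central nitrogen and gives 31800 nM, the lowest of the three numbers, though compound 1 and compound 2 both lie within the usual scatter of it.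

Compound 4 `Fc1ccccc1-c1cc(CN(c2ncccn2)c2nc3ccccc3s2)on1` is the next compound, not yet measured. It differs from compound 3 in one place: 2-fluorophenyl in place of 4-(trifluoromethoxy)phenyl on an aromatic carbon. For the measured compounds named here, this is the same kind of swap as the one from compound 1 to compound 2, an exchange of one aryl group for another at that ring carbon, and that swap moved the number by a 1.6-fold higher number from compound 1 to compound 2 (0.20 log units; within the scatter). On that basis, no step beyond the scatter is expected for compound 4 in this assay. The estimated step is a 1.1-fold higher number from compound 3 to compound 4 (0.04 log units; within the scatter). For compound 4 the expected value is 35000 nM, with a range from 15000 nM to 80000 nM.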

Compound 4, half-maximal inhibitory concentration: 25400 nM
Beside the measured number, compound 4's estimate is 1.4-fold (0.14 log units) above it, within the range that was stated.
By their numbers in this assay, from the lowest: compounds 4, 3, 1 and 2 (each within the scatter of the next, the first and the last beyond it).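

In this assay, removing the 4-(trifluoromethoxy)phenyl group and placing 2-fluorophenyl, a group with fewer heavy atoms and a different fluorine-bearing substituent, on the same aromatic carbon gives a 1.3-fold lower number from compound 3 to compound 4 (0.10 log units; within the scatter). This is the second exchange of one aryl group for another at this carbon, and it was made with a different pair of groups on the central nitrogen from the first, yet both steps stay within the scatter, so across these four compounds no aryl exchange at this position has produced a clear change in the number. No measurement at hand offers an explanation for this result.

The compounds shown carry only aryl groups at this carbon, so they say nothing about how an amine or a carboxylic acid on a short chain would behave there. Compound 1 and compound 3 differ in more than one place, which leaves the contribution of the groups on the central nitrogen unread.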